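The source may report more compounds than this note shows. Statements on the series, on what has been measured and on what is new or still open speak of the compounds shown alone.

In a functional assay on 143B cells (Homo sapiens) for inhibition, read by CCK-8 assay, with a stated time of 72 h, tested at 1 uM (on this read-out higher numbers stand for more inhibition at the one concentration tested (going by the name of the read-out) and lower numbers for less inhibition), the measured compounds are:
compound 1 `O=C(NCCCCc1ccccc1)c1cccc(C2SCC(=O)N2c2cccc(F)c2)c1`, 63%
compound 2 `CCOc1ccccc1N1C(=O)C(C)SC1c1cccc(C(=O)NCCCCc2ccccc2)c1`, 53%
compound 3 `COc1ccccc1N1C(=O)CSC1C(=O)NCCCCc1ccccc1`, 4%

Compound 1 gives the highest of these three numbers. Compound 2 sits close beneath it, within the usual scatter, so the two cannot be told apart; compound 3 lies far beneath, well beyond the scatter. The unmeasured compound 4 `COc1ccc(N2C(=O)CSC2c2cccc(C(=O)NCCCCc3ccccc3)c2)c(OC)c1` keeps the core of compound 1 and changes one group: 2,4-dimethoxyphenyl in place of 3-fluorophenyl on an amide-type nitrogen in a ring. Going by the values given here, no measured pair shows this exact change. Among the compounds with values here, compound 2, the only other measured compound carrying a different group on the amide-type nitrogen in the ring, stays within the scatter of compound 1. The step of a number 11 percentage points lower from compound 1 to compound 4 (beyond the scatter) is therefore expected to be small, downward if anything, and not clearly beyond the scatter. Compound 4 is estimated at 52%, between 28% and 72%.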

Compound 4, a percentage reported as inhibition, at one concentration (the size of the read-out at that concentration, not a potency): 53%
Compound 4: middle estimate off by 1 percentage points, on the low side, and the stated range covers the measured number.
By their numbers in this assay, from the lowest: compound 3; then compounds 2, 4 and 1 (each within the scatter of the next).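

In this assay putting 2,4-dimethoxyphenyl in place of 3-fluorophenyl on the amide-type nitrogen in the ring gives a number 10 percentage points lower from compound 1 to compound 4 (within the scatter) on the core of compound 1. Going by these compounds alone, this is the first single-place comparison at this position, and it shows that a phenyl ring carrying two methoxy groups and no fluorine can sit here without a change that stands clear of the scatter. Nothing available explains this result. The compounds shown leave open how a plain phenyl, or a phenyl bearing an amine or a carboxylic acid, would read at this position.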